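Swapping the phenyl for a vinyl on the shared core

The compounds below may be only part of what the source reports. "The series", "measured", "known", "first", "only" and "open" are said of these compounds alone.

Compound 1 `c1ccc(-c2nc(-c3c[nH]c4ccccc34)co2)cc1` was tested in a functional assay on DU-145 cells (Homo sapiens) for cytotoxicity, read by MTT assay, with a stated time of 48 h (a higher number here means a weaker inhibitor, a lower number a stronger inhibitor), and gave 167000 nM. Its relative compound 2 `Clc1ccc(-c2nc(-c3c[nH]c4ccccc34)co2)cc1` gives 206000 nM in this assay, and the step of a 1.2-fold higher number from compound 1 to compound 2 (0.09 log units; within the scatter) stays within the scatter. Of these two numbers compound 1 holds the lowest, with compound 2 the nearest.

Compound 3 `C=Cc1nc(-c2c[nH]c3ccccc23)co1` has not yet been measured. It differs from compound 1 by vinyl in place of phenyl on an aromatic carbon. Among the measured compounds shown here, the only measured step, a 1.2-fold higher number from compound 1 to compound 2 (0.09 log units; within the scatter), touches a different part of the molecule and stayed within the scatter, so no measured step tells how trading the phenyl for a vinyl will move the number. With a group of 2 heavy atoms and no ring replacing a six-membered aromatic ring, a step beyond the scatter in this assay cannot be ruled out, yet nothing measured points in either direction. Compound 3 is therefore expected to give about 200000 nM, within a range from 80000 nM to 500000 nM. That estimate means an expected step of a 1.2-fold higher number from compound 1 to compound 3 (0.08 log units; within the scatter).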

Compound 3, half-maximal inhibitory concentration: 59800 nM
Beside the measured number, compound 3's estimate is 3.3-fold (0.52 log units) above it; the whole stated range lies above it.
By their numbers in this assay, from the lowest: compound 3; then compounds 1 and 2 (each within the scatter of the next).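

On the aromatic carbon next to the ring nitrogen and next to the ring oxygen, the number in this assay does respond to a change of group: vinyl in place of phenyl gives a 2.8-fold lower number from compound 1 to compound 3 (0.45 log units; beyond the scatter), and vinyl in place of 4-chlorophenyl gives a 3.4-fold lower number from compound 2 to compound 3 (0.54 log units; beyond the scatter). Unlike the chloro step on the phenyl, which stayed within the scatter, these steps show that a six-membered aromatic ring at this place is not needed for activity in this assay, and that the smaller vinyl group gives a modest gain. Nothing available explains why the number fell.

The compounds shown leave open whether the double bond matters or only the smaller size of the group; an ethyl or methyl group here would separate the two. From the compounds shown here alone, how an amine or a longer chain would behave at this place also remains open.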